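A few compounds are considered here, and "the series" means these few. Any claim that something is new, unique, unknown or untested is made for them only; others in the source may bear on it.

Working notes on the series. For the measured compounds named here, compound 2 `CN1[C@@H]2c3[nH]c4ccccc4c3C[C@H]1[C@H](C#N)N1[C@@H](CNC(=O)c3cc4ccccc4s3)c3[nH]c4ccccc4c3C[C@@H]21` carries the highest number of the two measured so far; in a functional assay on MCF7 cells (Homo sapiens) for cytotoxicity, read by MTT assay, with a stated time of 72 h (a higher number here means a weaker inhibitor, a lower number a stronger inhibitor), compound 2 gives 3180 nM. Its nearest neighbour is compound 1 `COc1ccc(C(=O)NC[C@H]2c3[nH]c4ccccc4c3C[C@H]3[C@H]4c5[nH]c6ccccc6c5C[C@@H]([C@H](C#N)N23)N4C)cc1`, and in this assay compound 1 gives 600 nM. Going by the values given here, the only measured step is a 5.3-fold higher number from compound 1 to compound 2 (0.72 log units; beyond the scatter). Compound 3 `CN1[C@@H]2c3[nH]c4ccccc4c3C[C@H]1[C@H](C#N)N1[C@@H](CNC(=O)c3cc4ccccc4[nH]3)c3[nH]c4ccccc4c3C[C@@H]21` is not yet measured; it differs from compound 2 in a single place: 1H-indol-2-yl in place of 1-benzothiophen-2-yl on a carbonyl carbon. The earlier step bears on this one only loosely, since it exchanged a different pair of groups on the same carbonyl carbon, and it showed that a swap at this position can move the number by a modest amount. Among the compounds with values here, no measured step reports the effect of the indole itself. The expected change is therefore small, with a lean towards a lower number, and compound 3 is expected to give 2000 nM (range 700 nM to 6000 nM), an expected step of a 1.6-fold lower number from compound 2 to compound 3 (0.20 log units; within the scatter).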

Compound 3, half-maximal inhibitory concentration: 9780 nM
Beside the measured number, compound 3's estimate is 4.9-fold (0.69 log units) below it; measured number above the stated range.
By their numbers in this assay, from the lowest: compound 1; then compound 2; then compound 3.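

In this assay, 1H-indol-2-yl in place of 1-benzothiophen-2-yl on the carbonyl carbon gives a 3.1-fold higher number from compound 2 to compound 3 (0.49 log units; beyond the scatter) and so shows that two groups of equal heavy-atom count, differing in sulfur against nitrogen and in the hydrogen-bond donor, are not interchangeable at this position. For the compounds shown here, the same group in place of 4-methoxyphenyl gives a 16-fold higher number from compound 1 to compound 3 (1.21 log units; beyond the scatter) as the largest step so far, which sets the three groups in the order 4-methoxyphenyl, 1-benzothiophen-2-yl, 1H-indol-2-yl, from lowest number to highest. No measurement on hand accounts for this order.

On these data alone, whether the hydrogen on the indole nitrogen is tied to the higher number stays open, and a 1-methyl-1H-indol-2-yl group on the same carbonyl carbon would address that. As far as these compounds go, how a plain phenyl or a 4-aminophenyl group would compare with 4-methoxyphenyl also remains open.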